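This account rests on a few compounds, and the source may have more. Where it says the series, first, only, none or still open, it means among the compounds named here.

Three compounds have been measured in a physicochemical assay for lipophilicity; a higher number here means a more lipophilic compound, a lower number a more polar compound:

Compound 1, `Cn1c(NC(=O)c2cccnc2)cc2ccccc21`, gives 1.3.
Compound 2, `O=C(Cn1ccccc1=O)Nc1cc2cccccc-2c1`, gives 1.7.
Compound 3, `CN(C)C(=O)c1cn(C)c2ccccc12`, gives 1.3.

Compound 3 stands level with compound 1 at the digits shown, and these two share the lowest value of the three. Compound 2 lies higher, by more than the usual scatter. Among the compounds with values here, none of the three measured compounds differs from another in only one place, so no single structural step among the measured values is available as a guide for what follows.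

The next compound, compound 4, `COC(=O)c1ccc2c(C(=O)N(C)C)cn(C)c2c1`, comes from compound 3 by one change: methoxycarbonyl in place of hydrogen on an aromatic carbon. Within the data shown here, with no measured step of this kind to lean on, the expected move is small, at most a slight rise, and may well stay within the scatter. In this assay the expected step is a number 0.10 log units higher from compound 3 to compound 4 (within the scatter). Compound 4 is therefore estimated at 1.4 in this assay, with a range from 0.9 to 1.9.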

Compound 4, partition coefficient: 1.4
The estimate for compound 4 equals the measured number at the digits printed, within the range that was stated.
By their numbers in this assay, from the lowest: compounds 1, 3, 4 and 2 (each within the scatter of the next, the first and the last beyond it).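

Within the data shown here, this is the first step in the set that changes only one place, so it gives a first reading for this position. In this assay, methoxycarbonyl in place of hydrogen on an aromatic carbon, meta to a fused ring and para to a fused ring, gives a step of a number 0.10 log units higher from compound 3 to compound 4 (within the scatter), so adding these 4 heavy atoms, 2 of them oxygen, leaves compound 4 indistinguishable from compound 3 in this measurement. No evidence is available to explain this result.

A single step cannot show whether a different group at this position, such as a carboxylic acid, an amine or a longer alkyl chain, would also stay within the scatter. It also leaves open whether methoxycarbonyl would give a similar reading on another carbon of the same ring.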